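The compounds below may be only part of what the source reports. "The series", "measured", "known", "first", "only" and "open" are said of these compounds alone.

Working notes on the series. Among the measured compounds shown here, in a functional assay on DLD-1 cells (Homo sapiens), read by microscopy and crystal violet staining, with a stated time of 20 h, tested at 10 ug/mL (on this read-out higher numbers stand for more inhibition at the one concentration tested (going by the name of the read-out) and lower numbers for less inhibition), compound 1 `O=C1NC(=S)S/C1=C\C=C\c1ccccc1` gives 81%; the only other number recorded is that of compound 2 `O=C1NC(=S)S/C1=C\C=C\c1ccccc1OS(=O)(=O)c1ccccc1`, which gives 80% in this assay, a gap within the scatter, so neither compound can be placed above the other. Compound 3 `O=C1NC(=S)S/C1=C\C=C\c1ccccc1OCc1ccncc1` has not been measured yet. It differs from compound 1 by (pyridin-4-yl)methoxy in place of hydrogen on an aromatic carbon. For the measured compounds named here, no step between measured compounds is available to guide the estimate; compound 2 carries its own substituent on the shared core and its value sits within the scatter of compound 1. The step of a number 3 percentage points lower from compound 1 to compound 3 (within the scatter) is therefore expected to be none beyond the scatter. Compound 3 is estimated at 78%, between 60% and 92%.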

Compound 3, a percentage reported as inhibition, at one concentration (the size of the read-out at that concentration, not a potency): 62%
The estimate for compound 3 lay 16 percentage points above the measured number; measured number inside the range.
By their numbers in this assay, from the lowest: compound 3; then compounds 2 and 1 (each within the scatter of the next).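

Placing (pyridin-4-yl)methoxy in place of hydrogen on this aromatic carbon gives a number 19 percentage points lower from compound 1 to compound 3 (beyond the scatter) in this assay, the one step shown that lies beyond the scatter. Substitution on this aromatic carbon therefore does not always leave the read-out unchanged, although compound 2 gives 80%. No available evidence accounts for this drop. The compounds shown leave open whether the drop follows the ring nitrogen of the entering group or the group as a whole. A benzyloxy group or a methoxy group on the same carbon would help separate these possibilities.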